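The source may report more compounds than this note shows. Statements on the series, on what has been measured and on what is new or still open speak of the compounds shown alone.

Measured in a functional assay on MCF7 cells (Homo sapiens) for antiproliferative activity, read by MTT assay, with stated times of 24 h and 72 h; a higher number here means a weaker inhibitor, a lower number a stronger inhibitor:
Compound 1 `COc1cc(N2C(=O)[C@@H](Oc3ccccc3)[C@H]2c2cccc(O)c2)cc(OC)c1OC`: 54000 nM
Compound 2 `COc1cc(N)c([C@@H]2[C@H](Oc3ccccc3)C(=O)N2c2cc(OC)c(OC)c(OC)c2)cc1O`: 20000 nM

Compound 2 holds the lower of these two numbers, which makes it the stronger inhibitor of the pair in this assay. Compound 3 `COc1cc(N2C(=O)[C@@H](Oc3ccccc3)[C@H]2c2cccc(N)c2)cc(OC)c1OC` has not yet been measured. Its structure differs from that of compound 2 on a saturated ring carbon of the four-membered ring: a group of 7 heavy atoms (6 carbon, 1 nitrogen; one six-membered aromatic ring of carbon only) in place of a group of 10 heavy atoms (7 carbon, 1 nitrogen, 2 oxygen; one six-membered aromatic ring of carbon only), on a saturated ring carbon. Going by the values given here, only one measured step bears on this change: a 2.7-fold lower number from compound 1 to compound 2 (0.43 log units; beyond the scatter). That modest step came with the larger group entering. Compound 3 returns to a smaller group, like compound 1, so much of that improvement is expected to be lost. Among the compounds with values here, with only two measured compounds, this expectation remains loose. The expected change is a modest rise, a 2.0-fold higher number from compound 2 to compound 3 (0.30 log units; within the scatter). For compound 3 the estimated value is 40000 nM, with an expected range of 12000 nM to 100000 nM.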

Compound 3, half-maximal inhibitory concentration: 17000 nM
Compound 3: middle estimate off by 2.4-fold (0.37 log units), on the high side, within the range that was stated.
By their numbers in this assay, from the lowest: compounds 3 and 2 (each within the scatter of the next); then compound 1.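

In this assay, the smaller 3-aminophenyl group does not bring back the number of compound 1, as the step shows: a 1.2-fold lower number from compound 2 to compound 3 (0.07 log units; within the scatter). The larger group of compound 2 is therefore not needed to reach this level. The swap of amino for hydroxy on an aromatic carbon is the cleaner comparison, giving a 3.2-fold lower number from compound 1 to compound 3 (0.50 log units; beyond the scatter), although nothing shown explains why this single change matters.

From the compounds shown here alone, whether a methylamino or an acetamido group in place of the amino group would go further remains open. Going by these compounds, it is also open whether the amino group would keep this gain with a methoxy group in place of the phenoxy group on the four-membered ring.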